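The compounds below may be only part of what the source reports. "The series", "measured", "known", "first", "only" and "open" are said of these compounds alone.

Compound 1 `CC(=O)c1nc([C@@H](O)[C@H](O)[C@H](O)CO)cn1C` gives 33.6%
Compound 2 `Cc1nc(-c2nc([C@@H](O)[C@H](O)[C@H](O)CO)c[nH]2)cs1` gives 23%
Compound 3 `OC[C@@H](O)[C@@H](O)[C@H](O)c1c[nH]c(-c2ncccn2)n1` is not yet measured

In an in vivo ADME assay on the whole organism (strain 129/SvEvBrd x C57BL/6) for pharmacokinetics, with Mus musculus as the target (on this read-out higher numbers stand for higher oral bioavailability and lower numbers for lower oral bioavailability), compound 2 gives 23% as the lower of the two numbers and compound 1 gives 33.6% as the higher. The gap between these two compounds lies beyond the scatter. The change to compound 3 is pyrimidin-2-yl in place of 2-methyl-1,3-thiazol-4-yl on an aromatic carbon and it sits on an aromatic carbon between two ring nitrogen atoms. Among the compounds with values here, no measured pair shows a change in one place, so no step beyond the scatter is expected in this assay. The expectation starts from compound 2 at 23% as its anchor. The expected step is a number 2 percentage points higher from compound 2 to compound 3 (within the scatter) within the scatter. Compound 3 is estimated at 25% with an expected range from 12% to 42% in this read-out.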

Compound 3, oral bioavailability: 7%
Compound 3: the middle estimate sits 18 percentage points above what was measured; the measured number lies below the stated range.
By their numbers in this assay, from the lowest: compound 3; then compound 2; then compound 1.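

On an aromatic carbon between two ring nitrogen atoms, pyrimidin-2-yl in place of 2-methyl-1,3-thiazol-4-yl gives a number 16 percentage points lower from compound 2 to compound 3 (beyond the scatter) in this assay, so this position does affect the read-out. The two groups have the same counts of heavy atoms, hydrogen-bond donors and hydrogen-bond acceptors, so those counts do not account for the difference. Nothing on hand bears on what lies behind this step.

Still open, going by these compounds, is how a phenyl ring, an amine or a carboxylic acid at this position would read. One step also cannot show whether the trend extends beyond these two groups.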